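Replacing Dichlorophenyl with Dimethoxyphenyl: Expected Shift in Cytotoxicity

The source may hold more compounds than are shown below. What is called first, only, known or untested is meant among the compounds shown, and "the series" means these compounds.

In a functional assay on UACC-62 cells (Homo sapiens) for cytotoxicity, read by sulforhodamine B assay, with a stated time of 48 h, tested at 10 uM (on this read-out lower numbers stand for a stronger effect and higher numbers for a weaker effect at the one concentration tested), compound 1 `COc1cc(-c2cc(/C=C/C(=O)c3ccc(Cl)c(Cl)c3)[nH]n2)cc(OC)c1OC` gives 63%, the highest of the three numbers recorded and therefore the weakest effect. Compound 2 `COc1ccc(-c2cc(/C=C/C(=O)c3ccc(N)cc3)[nH]n2)cc1OC` gives 3%, a gap from compound 1 beyond the usual scatter. Compound 3 `COc1ccc(-c2cc(/C=C/C(=O)c3cc(OC)c(OC)c(OC)c3)[nH]n2)cc1OC` gives -61%, the furthest below compound 1, again beyond the scatter.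

Compound 4 `COc1ccc(C(=O)/C=C/c2cc(-c3cc(OC)c(OC)c(OC)c3)n[nH]2)cc1OC` has not yet been measured in this assay. It differs from compound 1 at a single place: 3,4-dimethoxyphenyl in place of 3,4-dichlorophenyl on a carbonyl carbon. Going by the values given here, no measured pair shows this exact change, so its size is open. Both compound 2 and compound 3 lie far below compound 1. A downward step beyond the usual scatter is expected, estimated as a number 63 percentage points lower from compound 1 to compound 4 (beyond the scatter). Compound 4 is therefore estimated at 0%, within a range from -50% to 50%.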

Compound 4, a percentage reported as activity, at one concentration (the size of the read-out at that concentration, not a potency): -92%
Beside the measured number, compound 4's estimate is 92 percentage points above it; the measured number lies below the stated range.
By their numbers in this assay, from the lowest: compound 4; then compound 3; then compound 2; then compound 1.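

In this assay, going by these compounds alone, 3,4-dimethoxyphenyl in place of 3,4-dichlorophenyl on a carbonyl carbon gives a number 155 percentage points lower from compound 1 to compound 4 (beyond the scatter) and is the first single-place change that can be read here. It shows that, with the rest of compound 1 held fixed, the group at this position alone can move the read-out far. No measurement available here bears on why the step is so large.

Open, from the compounds shown here alone, is how a 3,4-difluorophenyl or a carboxylic acid-bearing phenyl would read on this carbonyl carbon. Also open, going by these compounds, is whether the same exchange gives a step of like size on a different core.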